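The compounds below may be only part of what the source reports. "The series", "measured", "known", "first", "only" and "open" are said of these compounds alone.

The measured compounds:

Compound 1 `Nc1cc(-c2cnc3[nH]cc(-c4ccncc4)c3c2)ccc1Cl` gives 12000 nM in a functional assay on MCF7 cells (Homo sapiens) for cytotoxicity, read by MTT assay, with a stated time of 48 h; a lower number here means a stronger inhibitor, a higher number a weaker inhibitor.
Compound 2 `CC(=O)Nc1cc(N)cc(-c2cnc3[nH]cc(-c4ccncc4)c3c2)c1` gives > 30000 nM in this assay; that is a limit of the measurement, not a number.
Compound 3 `Cc1ccc(S(=O)(=O)Nc2cc(N)cc(-c3cnc4[nH]cc(-c5ccncc5)c4c3)c2)cc1` gives 10400 nM in this assay.

Among the numbers shown, compound 3 and compound 1 sit within the usual scatter of each other, so neither can be placed ahead of the other; the remaining value, that of compound 2, is only a limit. Among the compounds with values here, the one measured step that touches the sulfonamide is the change from acetyl to (4-methylphenyl)sulfonyl on the ring nitrogen, which gave an at least 2.8-fold lower number from compound 2 to compound 3 (0.46 log units; beyond the scatter). Compound 4 `CS(=O)(=O)Nc1cc(N)cc(-c2cnc3[nH]cc(-c4ccncc4)c3c2)c1` differs from compound 3 by methyl in place of 4-methylphenyl on a sulfonyl sulfur. That step runs the other way from the measured one: the group that leaves is the very group whose arrival lowered the number, and what replaces it is a smaller sulfonyl substituent. A move back toward a weaker number is therefore expected, though its size is uncertain, since the limit of > 30000 nM in this assay, at which 1 of the 3 values shown sits, means the earlier step is known only as a lower bound. Compound 4 is expected to give about 20000 nM, in a range from 8000 nM to 50000 nM, which corresponds to an estimated step of a 1.9-fold higher number from compound 3 to compound 4 (0.28 log units; within the scatter).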

Compound 4, half-maximal inhibitory concentration: > 30000 nM
Compound 4: no number, only a limit; the forecaster's own chance of this, stated with the estimate: 35%; middle value at least 1.5-fold (0.17 log units) away from the limit.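

In this assay compound 4 gives > 30000 nM, which is a limit of the measurement and not a number. The 4-methylphenyl on the sulfonyl sulfur therefore matters in its own right: replacing it with methyl, a single carbon in place of seven, gives an at least 2.8-fold higher number from compound 3 to compound 4 (0.46 log units; beyond the scatter), so the sulfonamide link alone does not carry the lower number, and the gain seen earlier on moving away from acetyl cannot be credited to the sulfonyl group by itself. Acetyl and methylsulfonyl on the ring nitrogen cannot be put in order, and the step between their two compounds cannot be read: the limit of > 30000 nM in this assay, at which 2 of the 4 values shown sit.

The compounds shown leave open whether the ring of the 4-methylphenyl is enough or its methyl also counts, a question that a plain phenyl on the same sulfur would address. They also do not tell whether a longer chain such as butyl could stand in for the ring, or whether a ring carrying a methoxy group or a chlorine in place of the methyl would bring the number lower still.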